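Propargylsulfanyl in place of 4-fluorobenzylsulfanyl on a shared core

The compounds below may be only part of what the source reports. "The series", "measured", "known", "first", "only" and "open" are said of these compounds alone.

Compound 1 `Cc1cc(Nc2cc(-c3ccccc3)[nH]n2)n2nc(SCc3ccc(F)cc3)nc2n1`: 3270 nM
Compound 2 `Cc1ccc(Cn2ccc(Nc3cc(C)nc4nc(SCc5ccc(Br)cc5)nn34)n2)cc1`: 7420 nM

In a functional assay on MGC-803 cells (Homo sapiens) for inhibition, read by MTT assay, with a stated time of 72 h (on this read-out higher numbers stand for weaker inhibition and lower numbers for stronger inhibition), compound 1 gives 3270 nM, the lowest of the two numbers shown, while compound 2 gives 7420 nM, a higher number that lies beyond the usual scatter. Compound 3 `C#CCSc1nc2nc(C)cc(Nc3cc(-c4ccccc4)[nH]n3)n2n1` differs from compound 1 in one place: ethynyl in place of 4-fluorophenyl on a saturated chain carbon bound to a sulfur. Within the data shown here, no measured pair shows this change, so the step can only be estimated. The step of a 2.0-fold higher number from compound 1 to compound 3 (0.30 log units; within the scatter) is expected to run toward weaker inhibition, beyond the scatter but not large. Compound 3 is therefore expected to give about 6500 nM in this assay, between 2200 nM and 20000 nM.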

Compound 3, half-maximal inhibitory concentration: 13400 nM
The estimate for compound 3 lay 2.1-fold (0.31 log units) below the measured number, within the range that was stated.
By their numbers in this assay, from the lowest: compound 1; then compounds 2 and 3 (each within the scatter of the next).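

In this assay, the change from (4-fluorobenzyl)sulfanyl to propargylsulfanyl gives a 4.1-fold higher number from compound 1 to compound 3 (0.61 log units; beyond the scatter), a modest step toward weaker inhibition. This pair, the only one here that differs in one place, shows that inhibition at this position responds to what is carried on the saturated chain carbon bound to the sulfur. No measurement shown bears on why the step arises.

The compounds shown leave open whether the step tracks the loss of the 4-fluorophenyl ring or the arrival of the ethynyl group. An unsubstituted benzyl or a propyl group at this place would help tell these apart.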